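The compounds below may be only part of what the source reports. "The series", "measured", "known", "first", "only" and "open" are said of these compounds alone.

Working notes on the series.

The shared core carries an aromatic oxygen with a short saturated chain ending in an amine. Compound 1, `NCCCOc1cccc2ccccc12`, is the lower of the two values measured in a functional assay for agonist activity at 5-hydroxytryptamine receptor 1B (Homo sapiens); a lower number here means a stronger inhibitor, a higher number a weaker inhibitor: compound 1 gives 290 nM. Compound 2, `CNCCCOc1ccccc1`, differs from compound 1 in more than one place; in this assay compound 2 gives 3450 nM, a markedly higher number, beyond the scatter.

Compound 3, `CCNCCOc1cccc2ccccc12`, has not yet been measured. It differs from compound 1 as follows: ethylamino in place of aminomethyl on a saturated chain carbon, two bonds along the chain from an oxygen on an aromatic ring. For the measured compounds named here, nothing measured isolates this change, so no step of the same kind is available for comparison. The expectation is a small step for compound 3, at most a modest move toward a higher number, and quite possibly none beyond the scatter; the estimated step is a 1.6-fold higher number from compound 1 to compound 3 (0.19 log units; within the scatter). For compound 3 the estimated value in this assay is 450 nM, expected to lie between 150 nM and 1400 nM.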

Compound 3, inhibition constant: 66 nM
Compound 3: middle estimate off by 6.8-fold (0.83 log units), on the high side; the whole stated range lies above it.
By their numbers in this assay, from the lowest: compound 3; then compound 1; then compound 2.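

Ethylamino in place of aminomethyl at this saturated chain carbon, two bonds along the chain from an oxygen on an aromatic ring, gives a 4.4-fold lower number from compound 1 to compound 3 (0.64 log units; beyond the scatter) in this assay, so this position responds to the change by more than the scatter, toward stronger inhibition. Cut one bond further out, the same difference reads 3-aminopropyl to 2-(ethylamino)ethyl, so the ethyl group on the nitrogen and the change in chain length arrive together, and this step alone cannot divide the effect between them. Nothing measured here accounts for the direction or the size of the step.

A 2-aminoethyl chain, or a 3-(ethylamino)propyl chain, on the same core would separate those two contributions. Going by these compounds, whether a larger group on the nitrogen, such as isopropyl, holds the lower number remains open.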